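Thiophene in Place of Methylphenyl on a Shared Core

The compounds below may be only part of what the source reports. "The series", "measured", "known", "first", "only" and "open" are said of these compounds alone.

Of the compounds shown here, three built on one core have been tested in a functional assay on the whole organism (strain Wister albino) for inhibition, with Rattus norvegicus as the target, read by paw edema, with stated times of 1 h and 2 h, at a dose of 50 mg/kg by the intraperitoneal route; a lower number here means less inhibition, a higher number more inhibition at the dose given (going by the name of the read-out). Compound 1 `CN1C(=O)[C@@]2(c3ccccc31)N(C)C[C@@H](c1ccco1)[C@@]21Cc2ccccc2C1=O` gives 33.1%, compound 2 `CN1C(=O)[C@@]2(c3ccccc31)N(C)C[C@@H](c1ccc(Cl)cc1)[C@@]21Cc2ccccc2C1=O` gives 36.3%, and compound 3 `Cc1ccc([C@@H]2CN(C)[C@]3(C(=O)N(C)c4ccccc43)[C@]23Cc2ccccc2C3=O)cc1` gives 8%, the lowest of the three. Compound 3 is set apart by a number 25.1 percentage points lower from compound 1 to compound 3 (beyond the scatter) and by a number 28.3 percentage points lower from compound 2 to compound 3 (beyond the scatter), whereas a number 3.2 percentage points higher from compound 1 to compound 2 (within the scatter) lies within the scatter. Compound 4 `CN1C(=O)[C@@]2(c3ccccc31)N(C)C[C@@H](c1cccs1)[C@@]21Cc2ccccc2C1=O` is not yet measured; it differs from compound 3 by thiophen-2-yl in place of 4-methylphenyl on a saturated ring carbon. The step that bears on this is a number 25.1 percentage points lower from compound 1 to compound 3 (beyond the scatter) read in reverse, since thiophen-2-yl, like furan-2-yl, is a five-membered aromatic ring with one hetero atom. Compound 4 is therefore expected to climb by a number 22 percentage points higher from compound 3 to compound 4 (beyond the scatter) in this assay. The estimate for compound 4 is 30%, with a range from 15% to 45%.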

Compound 4, a percentage reported as inhibition, in the whole organism at one dose (the size of the read-out at that dose, not a potency): 10.8%
Compound 4: the middle estimate sits 19.2 percentage points above what was measured; measured number outside the range, below it.
By their numbers in this assay, from the lowest: compounds 3 and 4 (each within the scatter of the next); then compounds 1 and 2 (each within the scatter of the next).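

In this assay, a five-membered aromatic ring with one hetero atom does not by itself set the outcome at this saturated ring carbon: thiophen-2-yl and furan-2-yl part, with a number 22.3 percentage points lower from compound 1 to compound 4 (beyond the scatter). Thiophen-2-yl also parts from 4-chlorophenyl, with a number 25.5 percentage points lower from compound 2 to compound 4 (beyond the scatter), but not from 4-methylphenyl, with a number 2.8 percentage points higher from compound 3 to compound 4 (within the scatter). Nothing measured here explains this split. Going by these compounds, whether an unsubstituted phenyl or a pyridin-3-yl ring on this carbon would fall with compound 1 and compound 2 or with compound 3 and compound 4 remains open.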